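Cytotoxicity notes on a four-compound series

The compounds below may be only part of what the source reports. "The series", "measured", "known", "first", "only" and "open" are said of these compounds alone.

Measured so far in an ADME assay on NIH3T3 cells (Mus musculus) for cytotoxicity; on this read-out lower numbers stand for higher toxicity in this test and higher numbers for lower toxicity in this test:
- Compound 1 `Fc1cccc(COc2ccc(Nc3ncnc4cc(C#CCN5CCNCC5)sc34)cc2Cl)c1` gives a limit of the assay, > 50 uM.
- Compound 2 `COCC#Cc1cc2ncnc(Nc3ccc(OCc4cccc(F)c4)c(Cl)c3)c2s1` likewise gives a limit of the assay, > 50 uM.
- Compound 3 `Fc1cccc(COc2ccc(Nc3ncnc4sc(C#CCN5CCNCC5)cc34)cc2Cl)c1` gives 3.9 uM.

Within the data shown here, compound 3 carries the only number in this set; the other two values are limits. Compound 1 and compound 3 are built from the same atoms joined differently, and the difference between the two cores is not broken down here.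

From compound 1 to compound 2 the change is methoxy in place of piperazin-1-yl on a saturated chain carbon bound to a triple-bonded carbon. The step that the two limits leave unreadable from compound 1 to compound 2 has no readable size because the limit of > 50 uM in this assay, at which 2 of the 3 values shown sit, holds both of its ends.

Compound 4 `COCC#Cc1cc2c(Nc3ccc(OCc4cccc(F)c4)c(Cl)c3)ncnc2s1` is not yet measured. It stands to compound 3 exactly as compound 2 stands to compound 1: the change is methoxy in place of piperazin-1-yl on a saturated chain carbon bound to a triple-bonded carbon, and the place is worded identically in both cases, so this is the same change made on the core of compound 3 instead of the core of compound 1. The measured pair gives no size to carry over.

The expectation for compound 4 therefore rests on compound 3 giving 3.9 uM as the only anchor, with the earlier step contributing no direction; the step expected from compound 3 to compound 4 in this assay is taken as a 3.1-fold higher number from compound 3 to compound 4 (0.49 log units; beyond the scatter), leaning toward lower toxicity but with wide uncertainty. Compound 4 is expected to give about 12 uM, with a plausible spread from 4 uM to 50 uM.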

Compound 4, half-maximal toxic concentration: 1.7 uM
The estimate for compound 4 lay 7.1-fold (0.85 log units) above the measured number, outside the stated range (below it).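

In this assay, on the core of compound 3, methoxy in place of piperazin-1-yl on a saturated chain carbon bound to a triple-bonded carbon gives a 2.3-fold lower number from compound 3 to compound 4 (0.36 log units; beyond the scatter), so on this core the swap moves the read-out toward higher toxicity in this test, and the presence of piperazin-1-yl is not required for a measurable number. This does not show that the change carries over from one core to the other, since the same change on the core of compound 1 cannot be read, both of its ends being limits rather than numbers: the limit of > 50 uM in this assay, at which 2 of the 4 values shown sit. The series therefore offers a single sized step on one core and nothing of known size on the other, which supports no rule on the size or direction of this change across cores.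

Still open, as far as these compounds go, is where a morpholin-4-yl or a dimethylamino group on the same saturated chain carbon would fall on the core of compound 3 relative to compound 3 and compound 4. Also open, from the compounds shown here alone, is whether any such group on the core of compound 1 would give a number rather than a limit in this assay.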